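The source may report more compounds than this note shows. Statements on the series, on what has been measured and on what is new or still open speak of the compounds shown alone.

Measured so far:
- compound 1 `COc1cc(OC)c2sc(-c3ccc(N/C=C\C(=O)c4ccc(OC)c(O)c4)c(C)c3)nc2c1` gives 14300 nM 
- compound 2 `COc1cc(OC)c2sc(-c3ccc(N/C=C\C(=O)c4ccc(OC)c(O)c4)cc3)nc2c1` gives 10600 nM 

Both readings come from a functional assay on A549 cells (Homo sapiens) for antiproliferative activity, read by sulforhodamine B assay, with a stated time of 48 h (a lower number here means a stronger inhibitor, a higher number a weaker inhibitor), and they are the only two available. Compound 2 stands level with compound 1: a 1.3-fold lower number from compound 1 to compound 2 (0.13 log units; within the scatter) is a step inside the usual scatter, so the two cannot be told apart.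

The next compound is compound 3 `COc1cc(OC)c2sc(-c3ccc(N/C=C\C(=O)c4ccc(OC)c(F)c4)cc3)nc2c1`, which keeps the rest of compound 2 and alters one group. The change fluoro in place of hydroxy on an aromatic carbon turns 3-hydroxy-4-methoxyphenyl into 3-fluoro-4-methoxyphenyl, with fluoro in place of hydroxy on an aromatic carbon.

Among the compounds with values here, the one measured step is only a weak guide. It put hydrogen in place of methyl at another place and left the 3-hydroxy-4-methoxyphenyl group untouched. Within the data shown here, no measured compound shows what losing the hydroxy does, so no direction can be drawn, and no step beyond the scatter is the default expectation, held loosely. The estimated 1.1-fold higher number from compound 2 to compound 3 (0.05 log units; within the scatter) is therefore small, with wide uncertainty on either side. The value expected for compound 3 is 12000 nM in this assay and the estimated range runs from 4000 nM to 35000 nM for this reading.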

Compound 3, half-maximal inhibitory concentration: 5300 nM
Compound 3: middle estimate off by 2.3-fold (0.35 log units), on the high side; the measured number falls inside the stated range.
By their numbers in this assay, from the lowest: compounds 3, 2 and 1 (each within the scatter of the next, the first and the last beyond it).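

In this assay, fluoro in place of hydroxy gives a 2.0-fold lower number from compound 2 to compound 3 (0.30 log units; within the scatter), so the two compounds cannot be told apart. This is the first change shown on the 3-hydroxy-4-methoxyphenyl group, whereas the earlier step concerned a methyl elsewhere in the molecule. It shows that at this place, a hydroxy, counted with one hydrogen-bond donor and one hydrogen-bond acceptor, can give way to a fluoro, counted with neither, without a step beyond the scatter; no measurement at hand explains this result.

Only hydroxy and fluoro are shown at this place, so it remains open what a bare hydrogen, a chloro, an amine or a larger ethoxy group would do there, and whether any of them would give a step beyond the scatter. On these data alone, it also remains open whether fluoro in place of hydroxy would give a similar result in a compound that carries the methyl of compound 1.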